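Swapping the sulfonamide substituent in a prostaglandin receptor series

The source may report more compounds than this note shows. Statements on the series, on what has been measured and on what is new or still open speak of the compounds shown alone.

Of the compounds shown here, three have been tested in an assay on CHO cells for displacement of a labelled ligand from prostaglandin D2 receptor 2 (Homo sapiens), read by scintillation counting; on this read-out higher numbers stand for weaker inhibition and lower numbers for stronger inhibition. Compound 1 `COCCN(C)S(=O)(=O)c1ccc(C)c(C#Cc2cc(Cl)ccc2OCC(=O)O)c1` gives 4.1 nM, the lowest number of the three and therefore the strongest inhibition among them. Compound 2 `CC(C)(C)N1C(=O)c2ccc(C#Cc3cc(Cl)ccc3OCC(=O)O)cc2S1(=O)=O` gives 14 nM in this assay, and compound 3 `CCCS(=O)(=O)c1cccc(C#Cc2cc(C#N)ccc2OCC(=O)O)c1` gives 21 nM; both of these lie beyond the usual scatter from compound 1, so compound 1 stands clearly ahead.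

Compound 4 `CCN(CC)S(=O)(=O)c1ccc(C)c(C#Cc2cc(Cl)ccc2OCC(=O)O)c1` has not yet been measured. It differs from compound 1 in one place: diethylamino in place of (2-methoxyethyl)(methyl)amino on a sulfonyl sulfur. The group that leaves carries one hydrogen-bond acceptor and the group that enters carries none, but the rest of the molecule, including the shared core and the acid-bearing side chain, is unchanged. Within the data shown here, no measured pair here shows the effect of such a swap on a sulfonyl sulfur, so the expectation rests on the small size of the change alone. A step from compound 1 to compound 4 of a 1.3-fold higher number from compound 1 to compound 4 (0.13 log units; within the scatter) is expected, which means no shift beyond the scatter. Compound 4 is estimated to give 5.5 nM in this assay, with a range from 2 nM to 15 nM.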

Compound 4, inhibition constant: 3.4 nM
Estimate against measurement, compound 4: 1.6-fold (0.21 log units) above; low and high end bracket the measured number.
By their numbers in this assay, from the lowest: compounds 4 and 1 (each within the scatter of the next); then compounds 2 and 3 (each within the scatter of the next).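

In this assay, putting diethylamino in place of (2-methoxyethyl)(methyl)amino on a sulfonyl sulfur gives a 1.2-fold lower number from compound 1 to compound 4 (0.08 log units; within the scatter) and so no shift beyond the scatter. Among these compounds, this is the first pair in the set that differs in one place, and it shows that, for these two groups, the hydrogen-bond acceptor in the group that leaves is not needed to keep the number at this level. Nothing in the data explains why the two groups read alike.

Going by these compounds, how far this tolerance reaches remains open: a ring such as morpholine or piperidine on the sulfonyl sulfur, a plain amino group, or a longer chain ending in a hydroxyl could behave differently. Whether the same swap holds on another core is also unknown.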